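The source may hold more compounds than are shown below. What is called first, only, known or untested is meant among the compounds shown, and "the series" means these compounds.

Compound 1 `O=c1cc(-n2cc(COc3ccccc3)nn2)c2cc(Br)ccc2o1`: 1720 nM. Compound 2 `O=c1cc(-n2cc(COc3ccccc3Br)nn2)c2cc(Br)ccc2o1`: 28900 nM. Compound 3 `O=c1cc(-n2cc(COc3ccccc3O)nn2)c2cc(Br)ccc2o1`: 24800 nM.

In a functional assay on MCF7 cells (Homo sapiens) for antiproliferative activity, read by MTT assay, with a stated time of 48 h (on this read-out higher numbers stand for weaker inhibition and lower numbers for stronger inhibition), compound 1 gives the lowest number of the three: a 17-fold higher number from compound 1 to compound 2 (1.23 log units; beyond the scatter) and a 14-fold higher number from compound 1 to compound 3 (1.16 log units; beyond the scatter). Compound 2 and compound 3 differ by hydroxy in place of bromo on an aromatic carbon, which gave a 1.2-fold lower number from compound 2 to compound 3 (0.07 log units; within the scatter). The cores of compound 2 and compound 1 differ by hydrogen in place of bromo on an aromatic carbon. Compound 4 `O=c1cc(-n2cc(COc3ccccc3)nn2)c2cc(O)ccc2o1` is not yet measured and differs from compound 1 by hydroxy in place of bromo on an aromatic carbon. This is the same kind of change as from compound 2 to compound 3, but at another place: there on a six-membered aromatic ring of carbon only, ortho to a large group; here on a ring that is part of a fused or bridged system of two rings, meta and para to a fused ring. Within the data shown here, because the one measured instance, a 1.2-fold lower number from compound 2 to compound 3 (0.07 log units; within the scatter), lay within the scatter, a small step is expected, a 2.0-fold higher number from compound 1 to compound 4 (0.31 log units; beyond the scatter). Compound 4 is estimated at 3500 nM, between 1000 nM and 15000 nM.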

Compound 4, half-maximal inhibitory concentration: > 50000 nM
Compound 4: a limit, no number; the forecaster's own chance of this, stated with the estimate: 5%; at least 14-fold (1.15 log units) between middle value and limit.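

Hydroxy in place of bromo on the fused ring gave an at least 29-fold higher number from compound 1 to compound 4 (1.46 log units; beyond the scatter) in this assay. Compound 4 gives > 50000 nM, which is a limit of the assay and not a number. The change therefore did not carry over in size from the pair of compound 2 and compound 3 to the core of compound 1, though two pairs, each with the change at a different place, give no rule for other cores: the same change on two cores in this assay, a 1.2-fold lower number (0.07 log units; within the scatter) from compound 2 to compound 3 and an at least 29-fold higher number (1.46 log units; beyond the scatter) from compound 1 to compound 4, at least 33-fold (1.52 log units) apart, beyond the scatter of two such steps

The compounds shown leave open whether the large step follows from the loss of bromo or from the entry of hydroxy. They also leave open how compound 1 would compare with a chloro, methoxy or amino group at that place.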